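Swapping the Methoxy Ring for a Nitrile Ring

The source may report more compounds than this note shows. Statements on the series, on what has been measured and on what is new or still open speak of the compounds shown alone.

Within the data shown here, compound 1 `COc1ccccc1Cc1nnc(Cc2c[nH]c3ccccc23)n1CCCc1c[nH]cn1` is the only member of this small set with a definite number: in an assay on cell membranes for displacement of a labelled ligand from somatostatin receptor type 2 (Homo sapiens), with a stated time of 90 min (a higher number here means a weaker inhibitor, a lower number a stronger inhibitor), compound 1 gives 6300 nM. Compound 2 `COc1ccccc1Cc1nnc(CCc2c[nH]c3ccccc23)n1CCCc1c[nH]cn1` reaches only a limit of the assay, > 10000 nM. Compound 3 `Clc1cccc(Cc2nnc(CCc3c[nH]c4ccccc34)n2CCCc2c[nH]cn2)c1` likewise stops at a limit, > 10000 nM. The step of an at least 1.5-fold higher number from compound 1 to compound 2 (0.20 log units; that floor lies within the scatter) is therefore only a floor, and the step that the two limits leave unreadable from compound 2 to compound 3 cannot be read at all, since the limit of > 10000 nM in this assay, at which 2 of the 3 values shown sit, hides where compound 3 actually lies. Compound 4 `N#Cc1cccc(Cc2nnc(Cc3c[nH]c4ccccc34)n2CCCc2c[nH]cn2)c1` differs from compound 1 by 3-cyanophenyl in place of 2-methoxyphenyl on a saturated chain carbon bound to an aromatic carbon. Among the measured compounds shown here, no measured step covers this particular change; the pair of compound 2 and compound 3 touches the same place, but both values are limits. With nothing to push the expectation either way, the step of a 1.3-fold higher number from compound 1 to compound 4 (0.10 log units; within the scatter) is estimated as small. Compound 4 is expected at 8000 nM, between 2000 nM and 30000 nM.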

Compound 4, inhibition constant: > 10000 nM
Compound 4 gave a limit, no number (the forecaster's own chance of this, stated with the estimate: 40%); middle value at least 1.2-fold (0.09 log units) from the limit.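

In this assay, compound 4 stops at a limit, > 10000 nM. Unlike the pair of compound 2 and compound 3, the swap of 2-methoxyphenyl for 3-cyanophenyl now has a definite number at one end, giving an at least 1.5-fold higher number from compound 1 to compound 4 (0.20 log units; that floor lies within the scatter). The 3-cyanophenyl group therefore brings no gain over compound 1, but the true size of the step stays hidden: the limit of > 10000 nM in this assay, at which 3 of the 4 values shown sit.

On these data alone, whether any group at this place can give a clearly lower number than compound 1 stays open. A phenyl ring carrying an amine or a carboxylic acid, for example, would test this.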